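Swapping the Ketone Arm of an Oxazole for Chlorine

The source may report more compounds than this note shows. Statements on the series, on what has been measured and on what is new or still open speak of the compounds shown alone.

Two compounds carry the shared core. Compound 1 `CC(=O)c1coc(C(=O)CCCCCCc2ccccc2)n1` gives 123 nM in an assay on HEK-293T cells for inhibition of diacylglycerol lipase-alpha (Homo sapiens), read by colorimetric assay; on this read-out lower numbers stand for stronger inhibition and higher numbers for weaker inhibition. Going by the values given here, compound 2 `CC(C)(C)C(=O)c1coc(C(=O)CCCCCCc2ccccc2)n1` gives 479 nM in this assay, the higher of the two numbers; the only measured step, a 3.9-fold higher number from compound 1 to compound 2 (0.59 log units; beyond the scatter), is a modest weakening on enlarging the group on the carbonyl carbon. Compound 3 `O=C(CCCCCCc1ccccc1)c1nc(Cl)co1` is not yet measured. It differs from compound 2 in one place: chloro in place of (tert-butyl)carbonyl on an aromatic carbon. Among the compounds with values here, no measured step removes the carbonyl itself, so the step from compound 1 to compound 2 bears on it only loosely, as the sole hint that a smaller group at this position is not worse. Compound 3 is therefore expected to land near 300 nM, with a range of 60 nM to 1500 nM. The step of a 1.6-fold lower number from compound 2 to compound 3 (0.20 log units; within the scatter) is expected to stay within the scatter.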

Compound 3, half-maximal inhibitory concentration: 2400 nM
Compound 3: the middle estimate sits 8.0-fold (0.90 log units) below what was measured; measured number above the stated range.
By their numbers in this assay, from the lowest: compound 1; then compound 2; then compound 3.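

Going by these compounds alone, compound 3 is the first of the three in which the carbonyl-bearing arm on the aromatic carbon is gone, and the loss is plain in this assay: there is a 5.0-fold higher number from compound 2 to compound 3 (0.70 log units; beyond the scatter) and, against the smallest ketone arm, a 20-fold higher number from compound 1 to compound 3 (1.29 log units; beyond the scatter), a large step where tert-butyl in place of methyl was only modest. The earlier hint that a smaller group does better at this position therefore does not hold across all three compounds: chloro, with 1 heavy atom, gives the highest number, and compound 3 goes against any ordering by group size. Among these compounds, the two that keep a carbonyl at this position give the lower numbers.

Going by these compounds, whether an amine, a methoxy group or a carboxylic acid on this carbon would read closer to acetyl or to chloro stays open. Nothing shown here accounts for why the number rises on this change.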